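The source may report more compounds than this note shows. Statements on the series, on what has been measured and on what is new or still open speak of the compounds shown alone.

Compound 3 `COc1cc(-c2nn(-c3cccc(NC(=O)Nc4cccc(C(F)(F)F)c4)c3)cc2-c2ccncc2)ccc1Cl` gives 1230 nM in a functional assay on SW-620 cells (Homo sapiens) for inhibition, read by sulforhodamine B assay, with a stated time of 48 h; a higher number here means a weaker inhibitor of growth, a lower number a stronger inhibitor of growth. Among the three measured compounds this is the lowest number, but the gaps to compound 1 `O=C(Nc1cccc(-n2cc(-c3ccncc3)c(-c3ccc(Cl)c(O)c3)n2)c1)Nc1ccc(Cl)c(Cl)c1` at 1460 nM and to compound 2 `COc1cc(-c2nn(-c3cccc(NC(=O)c4cccc(C(F)(F)F)c4)c3)cc2-c2ccncc2)ccc1Cl` at 2310 nM are both within the scatter, so no order is claimed. Compound 4 `COc1cc(-c2nn(-c3cccc(NC(=O)c4ccccc4)c3)cc2-c2ccncc2)ccc1Cl` is the next analogue; it differs from compound 3 by phenyl in place of (3-(trifluoromethyl)phenyl)amino on a carbonyl carbon. Within the data shown here, only one measured step bears on this: a 1.9-fold lower number from compound 2 to compound 3 (0.27 log units; within the scatter), which is within the scatter. Among the measured compounds shown here, the move to compound 4 reverses that step and also removes the trifluoromethyl, and the numbers give no step for that removal alone. A small upward step is therefore expected, a 2.0-fold higher number from compound 3 to compound 4 (0.29 log units; within the scatter), because of a 1.9-fold lower number from compound 2 to compound 3 (0.27 log units; within the scatter). Compound 4 is estimated at 2400 nM in this assay, range 1000 nM to 6000 nM.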

Compound 4, concentration for 50% growth inhibition: 551 nM
Compound 4: middle estimate off by 4.4-fold (0.64 log units), on the high side; the whole stated range lies above it.
By their numbers in this assay, from the lowest: compound 4; then compounds 3, 1 and 2 (each within the scatter of the next).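

In this assay the position on the carbonyl carbon now gives steps beyond the scatter: a 4.2-fold lower number from compound 2 to compound 4 (0.62 log units; beyond the scatter) for hydrogen in place of trifluoromethyl on an aromatic carbon, and a 2.2-fold lower number from compound 3 to compound 4 (0.35 log units; beyond the scatter) for phenyl in place of (3-(trifluoromethyl)phenyl)amino. Read with the earlier step within the scatter, a 1.9-fold lower number from compound 2 to compound 3 (0.27 log units; within the scatter), the number moves with loss of the trifluoromethyl rather than with the amino link. No evidence at hand accounts for either step.

Open, from the compounds shown here alone, is whether the phenylamino counterpart of compound 4 matches it. Also open, going by these compounds, is how an amine or a nitrile on that phenyl would read.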